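Aryl swap on a dichlorophenyl core: from compound 2 to 3

The source may hold more compounds than are shown below. What is called first, only, known or untested is meant among the compounds shown, and "the series" means these compounds.

Measured so far:
compound 1, `Cc1cc(C)cc(-c2cc(Cl)cc(Cl)c2/C=C/[C@@H]2C[C@@H](O)CC(=O)O2)c1`, 13 nM;
compound 2, `O=C1C[C@H](O)C[C@@H](/C=C/c2c(Cl)cc(Cl)cc2-c2ccc(Cl)c(Cl)c2)O1`, 25 nM.

In an assay for inhibition of 3-hydroxy-3-methylglutaryl-coenzyme A reductase (Rattus norvegicus) (on this read-out lower numbers stand for stronger inhibition and higher numbers for weaker inhibition), compound 2 gives the highest of the two numbers, with compound 1 nearest, a step that lies within the scatter. Compound 3, `CCc1cccc(-c2cc(Cl)cc(Cl)c2/C=C/[C@@H]2C[C@@H](O)CC(=O)O2)c1`, carries the change (3-ethylphenyl in place of 3,4-dichlorophenyl on an aromatic carbon). Within the data shown here, the one measured step that bears on this position, a 1.9-fold higher number from compound 1 to compound 2 (0.28 log units; within the scatter), exchanged the same aromatic substituent and stayed within the scatter, so no step beyond the scatter is expected here either. Compound 3 is therefore expected to give 15 nM, between 6 nM and 40 nM. The expected step from compound 2 is a 1.7-fold lower number from compound 2 to compound 3 (0.22 log units; within the scatter).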

Compound 3, half-maximal inhibitory concentration: 44 nM
Estimate against measurement, compound 3: 2.9-fold (0.47 log units) below, and the stated range ends below it.
By their numbers in this assay, from the lowest: compounds 1, 2 and 3 (each within the scatter of the next, the first and the last beyond it).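

In this assay, among these compounds, the step of a 3.4-fold higher number from compound 1 to compound 3 (0.53 log units; beyond the scatter) is the first at this position to pass the scatter, so the choice of aryl group can shift the number here. The step of a 1.8-fold higher number from compound 2 to compound 3 (0.25 log units; within the scatter) stays within the scatter, so 3-ethylphenyl and 3,4-dichlorophenyl are not told apart. Nothing available explains the larger step. The compounds shown leave open how this position responds to an aryl group carrying an amine or a carboxylic acid. They also leave open whether a propyl chain in place of the ethyl group would move the number further.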